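From a Dimethylamino Chain to an Acetyl Chain

The source may hold more compounds than are shown below. What is called first, only, known or untested is meant among the compounds shown, and "the series" means these compounds.

Among the measured compounds shown here, in a functional assay (trachea) with Cavia porcellus as the target (a higher number here means that more compound is needed for the effect, a lower number that less compound is needed), compound 1 (`CCCn1c(=O)n(CC)c(=O)c2[nH]cnc21`) gives 1300 nM, while compound 2 (`CCCn1c(=O)n(CCCN(C)C)c(=O)c2[nH]cnc21`) gives 20500 nM, the higher of the two numbers so far. Compound 3 (`CCCn1c(=O)n(CCCCC(C)=O)c(=O)c2[nH]cnc21`) departs from compound 2 by 2-oxopropyl in place of dimethylamino on a saturated chain carbon, three bonds along the chain from an aromatic nitrogen. For the measured compounds named here, only one measured step bears on this change: a 16-fold higher number from compound 1 to compound 2 (1.20 log units; beyond the scatter), a large step that came with adding (dimethylamino)methyl. Going by the values given here, no measured compound carries the 4-acetylbutyl chain, so this guide is partial. With the dimethylamino group gone, much of that large rise is expected to be undone, though not all of it. The expected change is a 5.1-fold lower number from compound 2 to compound 3 (0.71 log units; beyond the scatter), a clear move toward a lower number in this assay. For compound 3 the estimated value is 4000 nM, with an expected range of 1000 nM to 16000 nM.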

Compound 3, half-maximal effective concentration: 60 nM
The estimate for compound 3 lay 67-fold (1.82 log units) above the measured number; measured number outside the range, below it.
By their numbers in this assay, from the lowest: compound 3; then compound 1; then compound 2.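

In this assay, the change at this chain end does far more than cancel the earlier rise: replacing dimethylamino with 2-oxopropyl gives a 340-fold lower number from compound 2 to compound 3 (2.53 log units; beyond the scatter) and reverses the direction seen with the first added chain. The 4-acetylbutyl chain also passes the short-chain reference, with a 22-fold lower number from compound 1 to compound 3 (1.34 log units; beyond the scatter) on record, so among these three compounds a longer chain at this nitrogen does not by itself bring a higher number, and the group at its end goes with the direction of the step. Nothing in hand explains why the two chain ends differ so sharply.

Still open is whether the low number follows the carbonyl or the chain length, as the compounds shown do not separate the two. A plain hexyl chain, or a carboxylic acid at the chain end, would bear on that question.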